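From Fluorine to Chlorine on the Benzyl Group

The compounds below may be only part of what the source reports. "The series", "measured", "known", "first", "only" and "open" are said of these compounds alone.

Compound 1 `CCC1(Cc2ccccc2)OS(=O)(=O)C=C1OCc1ccc(F)cc1` was tested in an ADME assay on HEL cells (Homo sapiens) for cytotoxicity, with a stated time of 3 days; on this read-out higher numbers stand for lower toxicity in this test and lower numbers for higher toxicity in this test. In this assay compound 1 gives >= 50000 nM, which is a limit of the assay rather than a measured number. Compound 2 `CCCC1(Cc2ccccc2)OS(=O)(=O)C=C1OCc1ccccc1` differs from compound 1 in more than one place and is included only for context. In this assay compound 2 gives >= 400000 nM, again a limit rather than a number. Of the two values shown, one sits at the limit of >= 400000 nM in this assay, at which 1 of the 2 values shown sits, and one at the limit of >= 50000 nM in this assay, at which 1 of the 2 values shown sits, so neither compound has revealed measurable toxicity within the tested range.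

Compound 3 `CCC1(Cc2ccccc2)OS(=O)(=O)C=C1OCc1cccc(Cl)c1` differs from compound 1 by 3-chlorophenyl in place of 4-fluorophenyl on a saturated chain carbon bound to an oxygen on an unsaturated carbon. Within the data shown here, with both measured values being limits, no measured step is available to guide the change. The step from compound 1 to compound 3 is therefore expected to be a number no higher from compound 1 to compound 3 (the limit leaves the size open), none beyond the scatter. Compound 3 is estimated at 50000 nM, within a range from 20000 nM to 400000 nM, most likely reported as a limit.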

Compound 3, minimum cytotoxic concentration: >= 20000 nM
Compound 3: no number, only a limit; the forecaster's own chance of this, stated with the estimate: 75%; the middle value lies beyond the limit too.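

Compound 1 and compound 3 are both recorded as limits rather than numbers in this assay, so no step can be read between them. The compounds shown leave open at what concentration each becomes toxic to these cells, and whether 3-chlorophenyl and 4-fluorophenyl differ at all.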